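Adding a second chloro group to compound 2

A few compounds are considered here, and "the series" means these few. Any claim that something is new, unique, unknown or untested is made for them only; others in the source may bear on it.

In a functional assay on AGS cells (Homo sapiens) for antiproliferative activity, read by MTT assay, with a stated time of 48 h (a higher number here means a weaker inhibitor of growth, a lower number a stronger inhibitor of growth), compound 1 (`COc1ccc(N(C)c2nc(Cl)nc3c2ncn3Cc2cc(OC)cc(OC)c2)cc1`) gives 69000 nM. Compound 2 (`COc1cc(Cn2cnc3c(Cl)ncnc32)cc(OC)c1`) reads > 100000 nM, which is a limit of this assay and not a number. Its true place on the scale is therefore open.

Compound 3 (`COc1cc(Cn2cnc3c(Cl)nc(Cl)nc32)cc(OC)c1`) differs from compound 2 in one place: chloro in place of hydrogen on an aromatic carbon. This is chloro in place of hydrogen on an aromatic carbon, between two ring nitrogen atoms.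

Within the data shown here, no measured pair isolates this change, so its size cannot be read directly. Compound 1 carries chloro on the same carbon and gives 69000 nM, but it also differs from compound 3 elsewhere, so it is only a loose guide. A modest move towards stronger growth inhibition is expected, and a reading that again reaches the limit of this assay remains a real possibility.

The estimated step of an at least 1.4-fold lower number from compound 2 to compound 3 (0.15 log units; that floor lies within the scatter) is small and is set against a limit rather than a number. For compound 3, the expected value is 70000 nM, with an estimated range of 25000 nM to 160000 nM.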

Compound 3, concentration for 50% growth inhibition: 3800 nM
Beside the measured number, compound 3's estimate is 18-fold (1.27 log units) above it; the measured number lies below the stated range.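

In this assay, chloro on the aromatic carbon between two ring nitrogen atoms gives an at least 26-fold lower number from compound 2 to compound 3 (1.42 log units; beyond the scatter), the first direct sign that this position responds strongly to a single added heavy atom. Going by these compounds, compound 2 reads as a limit and not a number, so this step is a floor and its full size stays unknown: the limit of > 100000 nM in this assay, at which 1 of the 3 values shown sits. Chloro in place of (4-methoxyphenyl)(methyl)amino on an aromatic carbon gives an 18-fold lower number from compound 1 to compound 3 (1.26 log units; beyond the scatter), which makes compound 3, with its two chloro groups and no such amino group, the strongest inhibitor of growth among the three compounds shown.

The compounds shown leave open whether the gain belongs to chloro as such, or whether a fluoro group, a methyl group or an amino group on the carbon between two ring nitrogen atoms would serve as well. They also leave open whether that chloro group keeps its effect when (4-methoxyphenyl)(methyl)amino stands on the other carbon, a question that needs the hydrogen counterpart of compound 1 set against compound 1 itself.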